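The compounds below may be only part of what the source reports. "The series", "measured", "known", "first", "only" and "open" are said of these compounds alone.

Two compounds have been measured in a functional assay on SK-HEP1 cells (Homo sapiens) for cytotoxicity, read by MTT assay, with a stated time of 48 h; on this read-out lower numbers stand for stronger inhibition and higher numbers for weaker inhibition:

Compound 1, `COc1cc2nc(Cl)nc(Nc3cccc(Cl)c3)c2cc1OC`: 16500 nM
Compound 2, `COc1cc2nc(Cl)nc(Nc3ccc(Oc4ccccc4)cc3)c2cc1OC`: 15300 nM

Both numbers are weak, and they sit close together. Compound 1 gives the higher number of the two, but its gap to compound 2 is within the scatter, so no order between them can be claimed. Compound 3, `COc1cc2nc(Cl)nc(Nc3ccc(O)c(C)c3)c2cc1OC`, has not yet been measured in this assay. It differs from compound 1 in one place: 4-hydroxy-3-methylphenyl in place of 3-chlorophenyl on a nitrogen on an aromatic ring. The shared core, with its methoxy groups and the chlorine on the ring, is untouched.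

Among the compounds with values here, no measured pair shows what this kind of exchange does here, so there is no step to lean on. Within the data shown here, with only two weak and similar numbers to go by, the most cautious expectation is a change in this assay that stays within the scatter, in either direction, with a modest chance of a somewhat lower number. The step from compound 1 to compound 3 is expected to be a 1.3-fold lower number from compound 1 to compound 3 (0.10 log units; within the scatter). Compound 3 is expected to give 13000 nM, with a likely range from 4000 nM to 40000 nM.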

Compound 3, half-maximal inhibitory concentration: > 40000 nM
Compound 3 was reported as a limit; the forecaster's own chance of this, stated with the estimate: 10%; middle value at least 3.0-fold (0.48 log units) from the limit.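

In this assay, compound 3 gives not a number but a limit of the assay, > 40000 nM. Exchanging 3-chlorophenyl for 4-hydroxy-3-methylphenyl on a nitrogen on an aromatic ring produces an at least 2.4-fold higher number from compound 1 to compound 3 (0.38 log units; beyond the scatter), showing that inhibition in these cells can respond to the group at this place, which the close values of compound 1 and compound 2 could not reveal. This step gives only a minimum size, and how much weaker inhibition becomes remains unknown: the limit of > 40000 nM in this assay, at which 1 of the 3 values shown sits.

The exchange removes the chlorine and brings in a hydroxy group and a methyl group at once, so the compounds shown cannot assign the loss of inhibition to any one of these parts, and a phenyl ring carrying only the hydroxy group or only the methyl group would be needed to separate them. Going by these compounds, it also remains open whether an amine or a carboxylic acid in place of the hydroxy group would give the same result, or whether any group at this place could bring a clearly lower number than compound 1 or compound 2.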